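The compounds below may be only part of what the source reports. "The series", "measured", "known", "first", "only" and "open" are said of these compounds alone.

Working notes on the series, cytotoxicity. Compound 1 `COc1ccc([C@H]2CC(C)(O)[C@@H]3CC[C@@H](C)C[C@H]3O2)cc1OC` gives in an ADME assay on MDCK cells (Canis lupus familiaris) for cytotoxicity, read by MTT assay, with a stated time of 48 h (on this read-out lower numbers stand for higher toxicity in this test and higher numbers for lower toxicity in this test), a value that is a limit of the assay, > 937000 nM. Compound 2 `COc1cc([C@H]2CC(C)(O)[C@@H]3CC[C@@H](C)C[C@H]3O2)cc(OC)c1OC` differs from compound 1 by methoxy in place of hydrogen on an aromatic carbon. In this assay compound 2 gives 405000 nM; the step of an at least 2.3-fold lower number from compound 1 to compound 2 (0.36 log units; beyond the scatter) rests on (the limit of > 937000 nM in this assay, at which 1 of the 3 values shown sits). Among the measured compounds shown here, compound 3 `C[C@@H]1CC[C@@H]2[C@@H](C1)O[C@@H](c1ccc(O)cc1)CC2(C)O` gives 127000 nM in this assay, the lowest of the numbers measured so far; the difference between its core and that of compound 1 is not broken down here. Compound 4 `COc1cc([C@H]2CC(C)(O)[C@@H]3CC[C@@H](C)C[C@H]3O2)ccc1O` awaits measurement and differs from compound 3 by methoxy in place of hydrogen on an aromatic carbon. This is the same kind of change as from compound 1 to compound 2, though the place differs: here the entering methoxy is ortho to a hydroxy group, there it is ortho to a methoxy group and meta to a methoxy group. Compound 4 is expected to show a step of similar modest size, a 1.6-fold lower number from compound 3 to compound 4 (0.20 log units; within the scatter), an expectation resting on an at least 2.3-fold lower number from compound 1 to compound 2 (0.36 log units; beyond the scatter). The estimate for compound 4 is 80000 nM, between 40000 nM and 200000 nM.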

Compound 4, half-maximal cytotoxic concentration: 411000 nM
For compound 4 the middle estimate is 5.1-fold (0.71 log units) below the measured one; the whole stated range lies below it.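

In this assay, methoxy in place of hydrogen on an aromatic carbon gives a 3.2-fold higher number from compound 3 to compound 4 (0.51 log units; beyond the scatter), so the change does not carry over from one core to the other, even in direction: the same change on two cores in this assay, an at least 2.3-fold lower number (0.36 log units; beyond the scatter) from compound 1 to compound 2 and a 3.2-fold higher number (0.51 log units; beyond the scatter) from compound 3 to compound 4, at least 7.4-fold (0.87 log units) apart, beyond the scatter of two such steps

Hydrogen in place of methyl on an oxygen on an aromatic ring gives an at least 2.2-fold lower number from compound 1 to compound 4 (0.35 log units; beyond the scatter), a step that, like the earlier methoxy step, starts from a limit of the assay for compound 1, not a number: the limit of > 937000 nM in this assay, at which 1 of the 4 values shown sits.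

This shows that the methoxy step cannot be transferred between these two cores, but it gives no cause and does not separate core from place, as the entering methoxy in compound 4 is ortho to a hydroxy group.

The compounds shown leave open how other groups would behave at this place, such as an amine or a carboxylic acid. They also leave open whether a longer chain on the oxygen would follow methoxy on either core.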